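A few compounds are considered here, and "the series" means these few. Any claim that something is new, unique, unknown or untested is made for them only; others in the source may bear on it.

Compound 1 `C[Se]c1nc(N)c2ccccc2n1` was tested in a functional assay on HTB-54 cells (Homo sapiens) for cytotoxicity, read by MTT assay, with a stated time of 72 h; a higher number here means a weaker inhibitor of growth, a lower number a stronger inhibitor of growth. In this assay compound 1 gives 88700 nM. Within the data shown here, only one other compound in this set yields a number: compound 3 `CCCCC[Se]c1nc(N)c2cccnc2n1`, which in this assay gives 51000 nM. The two numbers sit within the usual scatter of each other, so compound 1 and compound 3 cannot be told apart on this basis. Compound 2 `C[Se]c1nc([Se]C)c2cccnc2n1` was made as well, but in this assay compound 2 is recorded as "not determined" (no result reported), with no result reported for it.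

Compound 4 `Nc1nc([SeH])nc2ccccc12` has not yet been measured. It differs from compound 1 by a single change: hydrogen in place of methyl on a selenium — hydrogen in place of methyl on a selenium whose other neighbour is an aromatic carbon. Among the measured compounds shown here, no pair of measured compounds shows the effect of this particular change, so there is no step to lean on. The step expected from compound 1 to compound 4 in this assay is therefore small, a 1.3-fold lower number from compound 1 to compound 4 (0.10 log units; within the scatter), and not clearly beyond the scatter. For compound 4 the estimate in this assay is 70000 nM, with a range from 20000 nM to 200000 nM.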

Compound 4, concentration for total growth inhibition: 3630 nM
Compound 4: middle estimate off by 19-fold (1.29 log units), on the high side; measured number outside the range, below it.
By their numbers in this assay, from the lowest: compound 4; then compounds 3 and 1 (each within the scatter of the next).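

Putting hydrogen in place of methyl on a selenium gives, in this assay, a 24-fold lower number from compound 1 to compound 4 (1.39 log units; beyond the scatter) and so marks this selenium as a sensitive place on the shared core. Among these compounds, the earlier compounds offered no pair differing in one place, so only this step shows that losing a methyl of just one carbon can shift growth inhibition well beyond the scatter. No available measurement explains the size of this step.

Going by these compounds, it remains open whether a longer chain, such as an ethyl group, or a carboxylic acid on the same selenium would keep the number of compound 4 or return towards that of compound 1. On these data alone, it is equally open whether hydrogen in place of the pentyl chain on the core of compound 3 would bring a step of similar size.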